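The compounds below may be only part of what the source reports. "The series", "measured", "known", "first", "only" and "open" are said of these compounds alone.

Compound 1 `COc1cc(OC)c(C(=O)/C=C/c2ccccc2OC)c(OC)c1`: 8200 nM
Compound 2 `COc1cc(OC)c(C(=O)/C=C/c2ccccc2SC)c(OC)c1`: > 20000 nM (a limit)
Compound 3 `COc1cc(OC)c(C(=O)/C=C/c2ccc(Cl)cc2)c(OC)c1`: > 20000 nM (a limit)

Going by the values given here, in an ADME assay on cells (Fibroblast, Homo sapiens) for cytotoxicity, with a stated time of 48 h (a lower number here means a stronger inhibitor, a higher number a weaker inhibitor), compound 1 is the only one with a true number. Compound 3 has only a limit, > 20000 nM, and no number. It shares that position with compound 2, and the one crowded spot in this small set is the limit of > 20000 nM in this assay, at which 2 of the 3 values shown sit.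

Compound 4 `COc1cc(OC)c(C(=O)/C=C/c2ccc([N+](=O)[O-])cc2)c(OC)c1` differs from compound 3 at a single place, with nitro in place of chloro on an aromatic carbon, para to a large group: nitro in place of chloro on an aromatic carbon.

Among the compounds with values here, no measured step makes this swap, so the evidence is indirect. The nearest is an at least 2.4-fold higher number from compound 1 to compound 3 (0.38 log units; beyond the scatter), which brought in the 4-chlorophenyl group. The other readable step is an at least 2.4-fold higher number from compound 1 to compound 2 (0.38 log units; beyond the scatter). Both lie beyond the scatter and run toward higher numbers, away from compound 1. The remaining step, a step that the two limits leave unreadable from compound 2 to compound 3, tells nothing about size.

Within the data shown here, with these steps as the only guide, no change beyond the scatter is expected, and compound 4 may well return only a limit too. The expected change is a number no higher from compound 3 to compound 4 (the limit leaves the size open). For compound 4 the estimated value is 20000 nM, with an expected range from 7000 nM to 50000 nM.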

Compound 4, half-maximal inhibitory concentration: 7300 nM
Estimate against measurement, compound 4: 2.7-fold (0.44 log units) above; the range from low to high includes it.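

In this assay, nitro in place of chloro on an aromatic carbon, para to a large group, gives an at least 2.7-fold lower number from compound 3 to compound 4 (0.43 log units; beyond the scatter). Going by these compounds alone, the earlier readable steps all ran toward higher numbers, so this is the first step in the set to run toward a lower number, and it shows that the group at this place can decide whether the series gives a true number at all: compound 4 gives 7300 nM. The full size of the step stays unknown, since compound 3 has only a limit and the step is anchored at one end by that limit alone: the limit of > 20000 nM in this assay, at which 2 of the 4 values shown sit.

Only chloro and nitro are shown at this place, so two groups cannot tell whether the lower number belongs to nitro alone or would also come with other groups there. An amine or a carboxylic acid at the same place, or nitro on the ring position that carries methoxy in compound 1, would show whether the change follows the group, the position or both.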